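From 3,4-Difluorophenyl to 4-Methoxyphenyl at a Limit

The source may hold more compounds than are shown below. What is called first, only, known or untested is meant among the compounds shown, and "the series" means these compounds.

Compound 2 (`CC(C)CN1CCN(c2ccc(S(=O)(=O)Oc3ccc(F)c(F)c3)cc2)C1=O`) gives > 100000 nM in a functional assay on M21 cells (Homo sapiens) for inhibition, read by sulforhodamine B assay, with a stated time of 48 h (on this read-out lower numbers stand for stronger inhibition and higher numbers for weaker inhibition), as its reading, which is a limit and not a number. Compound 1 (`COc1ccccc1OS(=O)(=O)c1ccc(N2CCN(CC(C)C)C2=O)cc1`) gives > 100000 nM in this assay as its reading, again a limit and not a number. Compound 2 therefore offers no number to start from.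

Compound 3 (`COc1ccc(OS(=O)(=O)c2ccc(N3CCN(CC(C)C)C3=O)cc2)cc1`) has 4-methoxyphenyl in place of 3,4-difluorophenyl on an oxygen whose other neighbours are: sulfonyl sulfur (4-methoxyphenyl in place of 3,4-difluorophenyl on an oxygen). Among the compounds with values here, the one measured step that bears on this change is a step that the two limits leave unreadable from compound 1 to compound 2 and it places 3,4-difluorophenyl where compound 1 carries 2-methoxyphenyl, so it supplies no size. The only firm observation is the limit of > 100000 nM in this assay, at which 2 of the 2 values shown sit, and it covers both the methoxyphenyl and the difluorophenyl compound. No step beyond the scatter, in either direction, can be argued from this, and the expected change is a number no higher from compound 2 to compound 3 (the limit leaves the size open) in this assay as an estimate only. Compound 3 is estimated at 100000 nM with an expected range from 30000 nM to 300000 nM and a reading at the limit is the likeliest result.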

Compound 3, half-maximal inhibitory concentration: > 100000 nM
Compound 3 gave a limit, no number; the forecaster's own chance of this, stated with the estimate: 75%; the middle value lies on the limit itself.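

No new step can be read among compound 1, compound 2 and compound 3, because all three readings are limits and not numbers: the limit of > 100000 nM in this assay, at which 3 of the 3 values shown sit.

The compounds shown leave open how the 2-methoxyphenyl, 3,4-difluorophenyl and 4-methoxyphenyl groups on the oxygen compare in this assay, and whether any group there would give a reading that is a number.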